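Working notes: replacing methoxy with cyclopropyl

The compounds below may be only part of what the source reports. "The series", "measured", "known", "first", "only" and "open" are said of these compounds alone.

Measured in a functional assay on COLO 205 cells (Homo sapiens) for antiproliferative activity, read by MTT assay, with a stated time of 68 h; a higher number here means a weaker inhibitor, a lower number a stronger inhibitor:
- compound 1 `O=S(=O)(Nc1ccc(F)c(C#Cc2ccc3[nH]ncc3c2)c1F)c1cccnc1`: > 10000 nM
- compound 2 `COc1n[nH]c2ncc(C#Cc3c(F)ccc(NS(=O)(=O)c4cccnc4)c3F)cc12`: 89 nM

Compound 1 stands at > 10000 nM, which is a limit of the assay and not a number. Among the compounds with values here, compound 2, at 89 nM, holds the only actual number so far, so its place cannot be ranked within a wider spread of values.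

The next compound is compound 3 `O=S(=O)(Nc1ccc(F)c(C#Cc2cnc3[nH]nc(C4CC4)c3c2)c1F)c1cccnc1`. The change from compound 2 is cyclopropyl in place of methoxy on an aromatic carbon of the five-membered aromatic ring, next to the ring nitrogen. Within the data shown here, no measured pair isolates this change, so the only anchor is compound 2 at 89 nM. The gap between the two measured compounds is not a guide, since they differ in more than this one place.

In this assay the expected change, a 1.1-fold higher number from compound 2 to compound 3 (0.05 log units; within the scatter), is none beyond the scatter, with no direction favoured. For compound 3 the expected value is 100 nM. The estimated range for compound 3 runs from 25 nM to 400 nM.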

Compound 3, half-maximal inhibitory concentration: 61 nM
Estimate against measurement, compound 3: 1.6-fold (0.21 log units) above; measured number inside the range.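

In this assay, within the data shown here, the step of a 1.5-fold lower number from compound 2 to compound 3 (0.16 log units; within the scatter) is the first reading at this carbon of the five-membered aromatic ring, and it shows that cyclopropyl can stand in place of methoxy with no change beyond the scatter. The exchange adds a three-membered non-aromatic ring of carbon only and removes a hydrogen-bond acceptor at this place, yet the number stays within the scatter of compound 2. Neither the limit in this assay nor anything else shown gives a cause for this result.

Going by these compounds, an amine, a carboxylic acid or a longer chain on this carbon remains open, as both groups compared here carry no net charge and no hydrogen-bond donors, so the step says nothing about groups of those kinds. Among these compounds, also open is whether the same exchange would hold on the core of compound 1, which differs from compound 2 and compound 3 in more than one place and offers no step to either.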